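Working notes: propyl in place of isopropyl

A few compounds are considered here, and "the series" means these few. Any claim that something is new, unique, unknown or untested is made for them only; others in the source may bear on it.

Measured in a functional assay on cells (Burkitts lymphoma cell, Homo sapiens) for antiproliferative activity, read by MTT assay; a higher number here means a weaker inhibitor, a lower number a stronger inhibitor:
- compound 1 `c1ccc(/C(=N/Nc2nc3ccccc3o2)C2CC2)nc1` gives 185 nM
- compound 2 `C/C(=N\Nc1nc2ccccc2o1)c1ccccn1` gives 9 nM
- compound 3 `CC(C)/C(=N\Nc1nc2ccccc2o1)c1ccccn1` gives 14 nM

In this assay compound 3 gives 14 nM and stays within the scatter of compound 2 (a 1.6-fold higher number from compound 2 to compound 3 (0.19 log units; within the scatter)). Compound 1 lies well away (a 13-fold lower number from compound 1 to compound 3 (1.12 log units; beyond the scatter)).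

The next compound is compound 4 `CCC/C(=N\Nc1nc2ccccc2o1)c1ccccn1`, with propyl in place of isopropyl on a carbon with a double bond to nitrogen. For the measured compounds named here, three measured steps bear on this change, all at the same place. Compound 2 and compound 3 are not separated (a 1.6-fold higher number from compound 2 to compound 3 (0.19 log units; within the scatter)), whereas replacing cyclopropyl was a large step in both cases (a 21-fold lower number from compound 1 to compound 2 (1.31 log units; beyond the scatter) and a 13-fold lower number from compound 1 to compound 3 (1.12 log units; beyond the scatter)). Compound 1 therefore goes against any picture of free tolerance at this place. Propyl has no ring, so the closer guide is the pair of compound 2 and compound 3. However, no unbranched chain of this length has been measured in the series.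

No step beyond the scatter is expected, only a slight lean towards a higher number (a 1.4-fold higher number from compound 3 to compound 4 (0.15 log units; within the scatter)). For compound 4 the estimate is 20 nM with an expected range from 7 nM to 70 nM in this assay as the read-out.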

Compound 4, half-maximal inhibitory concentration: 6 nM
The estimate for compound 4 lay 3.3-fold (0.52 log units) above the measured number, outside the stated range (below it).
By their numbers in this assay, from the lowest: compounds 4, 2 and 3 (each within the scatter of the next, the first and the last beyond it); then compound 1.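

In this assay the same carbon count arranged as an unbranched chain instead of a branched one gives a step beyond the scatter (a 2.3-fold lower number from compound 3 to compound 4 (0.37 log units; beyond the scatter)), so this place on a carbon with a double bond to nitrogen is not indifferent to the swap of isopropyl for propyl, although the step is modest. Methyl and propyl remain unseparated (a 1.5-fold lower number from compound 2 to compound 4 (0.18 log units; within the scatter)), so the three open-chain groups do not fall into a simple order by chain size, as methyl stays within the scatter of both propyl and isopropyl, while cyclopropyl stands further apart than before (a 31-fold lower number from compound 1 to compound 4 (1.49 log units; beyond the scatter)) and compound 1 remains the exception to tolerance of small groups here. Nothing in the available data accounts for either the gap between the two chains or the distance of the ring compound.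

Left open is whether butyl or a longer chain stays in the range of compound 4, and whether a propyl chain carrying an amine or a hydroxyl is accepted at this place. Also open, as far as these compounds go, is whether cyclobutyl or another saturated ring would follow compound 1 rather than the open chains.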